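Acetyl to Dimethylamino: What Compound 3 Might Show

The source may hold more compounds than are shown below. What is called first, only, known or untested is meant among the compounds shown, and "the series" means these compounds.

Measured in a functional assay on SF-268 cells (Homo sapiens) for cytotoxicity, read by sulforhodamine B assay, with a stated time of 48 h, tested at 100 nM; on this read-out lower numbers stand for a stronger effect and higher numbers for a weaker effect at the one concentration tested:
compound 1 `COc1cc(C)cc(-c2c(-c3ccnc(-c4ccc(C(C)=O)cc4)c3)cnn2CC#N)c1` gives 85%
compound 2 `Cc1cc(O)cc(-c2nn(CC#N)cc2-c2ccnc(-c3ccc(N(C)C)cc3)c2)c1` gives 90%

Compound 1 stands at the lower of the two numbers shown, and its nearest neighbour, compound 2, sits within the usual scatter of it, so the two cannot be told apart. Compound 3 `COc1cc(C)cc(-c2c(-c3ccnc(-c4ccc(N(C)C)cc4)c3)cnn2CC#N)c1` differs from compound 1 by dimethylamino in place of acetyl on an aromatic carbon. Among the measured compounds shown here, no measured pair isolates this change, so its size is unknown. Compound 2 also carries dimethylamino at that position and gives 90%, which lies within the scatter of compound 1. The step of a number 3 percentage points higher from compound 1 to compound 3 (within the scatter) is therefore expected to be small, with no change beyond the scatter and, if anything, a slight upward drift. Compound 3 is estimated at 88%, with a range from 76% to 98%.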

Compound 3, a percentage reported as activity, at one concentration (the size of the read-out at that concentration, not a potency): 29%
For compound 3 the middle estimate is 59 percentage points above the measured one, and the stated range ends above it.
By their numbers in this assay, from the lowest: compound 3; then compounds 1 and 2 (each within the scatter of the next).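

In this assay, among the compounds shown here, dimethylamino in place of acetyl on this aromatic carbon gives a number 56 percentage points lower from compound 1 to compound 3 (beyond the scatter), the first step in this set that can be read beyond the scatter. It shows that the read-out at the one concentration tested is sensitive to the group at this place, even though the counts of heavy atoms, donors and acceptors under the change stay matched. Compound 2 also carries dimethylamino but differs from compound 3 elsewhere too, so it cannot isolate this change, and nothing measured here gives a reason for the step.

From the compounds shown here alone, it remains open whether a primary amine, a pyrrolidine ring or a carboxylic acid at this place would read like dimethylamino or like acetyl. Going by these compounds, it is also open whether the step would hold on the core of compound 2.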